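This account rests on a few compounds, and the source may have more. Where it says the series, first, only, none or still open, it means among the compounds named here.

Compound 1 `OCc1cnn(-c2nc(Nc3ccc(C(F)(F)F)cc3)c3ncn([C@@H]4O[C@H](CO)[C@@H](O)[C@H]4O)c3n2)c1`, compound 2 `O=C(O)c1cnn(-c2nc(NC34CCC(CC3)C4)c3ncn([C@@H]4O[C@H](CO)[C@@H](O)[C@H]4O)c3n2)c1` and compound 3 `CCOC(=O)c1cnn(-c2nc(NC34CCC(CC3)C4)c3ncn([C@@H]4O[C@H](CO)[C@@H](O)[C@H]4O)c3n2)c1` share one core and differ only in the groups attached to it. In an in vitro assay on HEK293 cells for displacement of a labelled ligand from adenosine receptor A2b (Homo sapiens) (on this read-out lower numbers stand for stronger inhibition and higher numbers for weaker inhibition), compound 1 gives > 6000 nM, which is a limit of the assay and not a number. In this assay compound 2 gives > 6000 nM, again a limit. In this assay compound 3 gives > 6000 nM, also a limit. Within the data shown here, compound 2 therefore stands only at a limit, and the single step between two measured compounds that differ in one place, a step that the two limits leave unreadable from compound 2 to compound 3, ethyl in place of hydrogen on an oxygen next to a carbonyl group, has no readable size, because all three values sit at the same limit (the limit of > 6000 nM in this assay, at which 3 of the 3 values shown sit).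

Compound 4 `O=C(O)c1cnn(-c2nc(N[C@H]3CCCO3)c3ncn([C@@H]4O[C@H](CO)[C@@H](O)[C@H]4O)c3n2)c1` has not yet been measured. It differs from compound 2 by a group of 5 heavy atoms (4 carbon, 1 oxygen; one five-membered non-aromatic ring with 1 hetero atom) in place of a group of 7 heavy atoms (7 carbon; 2 five-membered non-aromatic rings of carbon only), on a nitrogen on an aromatic ring. Among the measured compounds shown here, no measured step touches this position, and the one measured step is unreadable, so nothing supports expecting a shift beyond the scatter in this assay. Compound 4 is therefore expected near 9000 nM, within 3000 nM to 40000 nM. This expected step, a step that the limit leaves unreadable from compound 2 to compound 4, rests on the limit of compound 2 alone.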

Compound 4, inhibition constant: > 6000 nM
Compound 4: a limit, no number; the forecaster's own chance of this, stated with the estimate: 75%; the middle value does not contradict the limit.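

Compound 2 and compound 4 both stand at a limit of the assay and not at a number, so no size can be read for the step between them: the limit of > 6000 nM in this assay, at which 4 of the 4 values shown sit. The compounds shown leave open how strongly any of them acts in this assay, and whether oxolan-2-yl on that nitrogen changes anything there.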